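The compounds below may be only part of what the source reports. "The series", "measured", "known", "first", "only" and "open" are said of these compounds alone.

Measured values in an ADME assay on MT4 cells (Homo sapiens) for cytotoxicity, read by MTT assay, with a stated time of 4 days; on this read-out lower numbers stand for higher toxicity in this test and higher numbers for lower toxicity in this test:
Compound 1, `Cc1cc(-c2cccc(F)c2)cc(C)c1Nc1ccnc(Nc2ccc(C#N)cc2)n1`, gives 4120 nM.
Compound 2, `COc1ccccc1-c1cc(C)c(Nc2ccnc(Nc3ccc(C#N)cc3)n2)c(C)c1`, gives 940 nM.
Compound 3, `COc1cccc(-c2cc(C)c(Nc3ccnc(Nc4ccc(C#N)cc4)n3)c(C)c2)c1`, gives 2990 nM.

Compound 3 stands second highest of the three numbers. Its nearest neighbour is compound 1, and that pair sits within the scatter: a 1.4-fold lower number from compound 1 to compound 3 (0.14 log units; within the scatter). Its furthest is compound 2, separated by a step beyond the scatter: a 3.2-fold higher number from compound 2 to compound 3 (0.50 log units; beyond the scatter).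

Compound 4, `Cc1cc(-c2ccccc2Cl)cc(C)c1Nc1ccnc(Nc2ccc(C#N)cc2)n1`, has not yet been measured in this assay. 2-chlorophenyl in place of 3-methoxyphenyl on an aromatic carbon Two measured steps bear on this change. The step with 3-methoxyphenyl in place of 2-methoxyphenyl gave a higher number, a 3.2-fold higher number from compound 2 to compound 3 (0.50 log units; beyond the scatter), and the step with 2-methoxyphenyl in place of 3-fluorophenyl gave a lower number, a 4.4-fold lower number from compound 1 to compound 2 (0.64 log units; beyond the scatter), while the methoxy for fluoro step alone stayed within the scatter, a 1.4-fold lower number from compound 1 to compound 3 (0.14 log units; within the scatter). Both informative steps point the same way, so compound 4 is expected to show a modest lower number, beyond the scatter: a 2.7-fold lower number from compound 3 to compound 4 (0.43 log units; beyond the scatter). Compound 4 is therefore estimated at 1100 nM, in a range from 450 nM to 2800 nM.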

Compound 4, half-maximal cytotoxic concentration: 3990 nM
For compound 4 the middle estimate is 3.6-fold (0.56 log units) below the measured one; measured number outside the range, above it.
By their numbers in this assay, from the lowest: compound 2; then compounds 3, 4 and 1 (each within the scatter of the next).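

In this assay, the 2-chlorophenyl group cannot be told apart from the two groups already tried in the other compounds: a 1.3-fold higher number from compound 3 to compound 4 (0.13 log units; within the scatter) and a 1.0-fold lower number from compound 1 to compound 4 (0.01 log units; within the scatter). Chloro in place of methoxy on the 2-substituted phenyl, by contrast, gives a 4.2-fold higher number from compound 2 to compound 4 (0.63 log units; beyond the scatter), so among these compounds the low number goes with the 2-methoxyphenyl group and not with a 2-substituted phenyl as such. Nothing available explains why the methoxy and chloro groups differ here.

The compounds shown leave open how a 3-chlorophenyl group would compare with the 2-chlorophenyl group. They also leave open whether a 2-hydroxyphenyl or 2-aminophenyl group would fall with compound 2 or with the other three compounds.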